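Metabolic stability of a shared core with varied ring substituents

The compounds below may be only part of what the source reports. "The series", "measured", "known", "first", "only" and "open" are said of these compounds alone.

Of the compounds shown here, three built on one shared core have been measured in an ADME assay on microsomes from liver (Mus musculus) for metabolic stability, read by LC-MS, using NADPH, with a stated time of 10 min, tested at 10 uM; a higher number here means that the compound lasts longer, a lower number that the compound disappears faster. Compound 1 `CC(C)(C)n1nc(Oc2cc(O)ccn2)c2c(N)ncnc21` gives 0.617 h in this assay. Compound 2 `Nc1ncnc2c1c(Oc1cccc(C(F)(F)F)c1)nn2[C@H]1C[C@H](O)C1` gives 0.367 h in this assay. Compound 3 `Nc1ncnc2c1c(Oc1cc(C(F)(F)F)ccn1)nn2[C@H]1CC[C@@H](N)CC1` gives 0.917 h in this assay, the highest of the three numbers; its gap to compound 1 lies within the scatter of repeated measurements, while its gap to compound 2 lies beyond it. No two of these compounds differ in a single place, so none of the measured pairs shows what one isolated change does here.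

Compound 4 `CO[C@H]1CC[C@H](n2nc(Oc3cc(C(F)(F)F)ccn3)c3c(N)ncnc32)CC1` has not yet been measured. It differs from compound 3 in one place: 4-methoxycyclohexyl in place of 4-aminocyclohexyl on an aromatic nitrogen. Going by the values given here, nothing among the measured compounds shows what this change does in this assay. The expected step is therefore small, with no clear direction, and most likely within the scatter. Compound 4 is estimated to give 0.75 h in this assay, within a range from 0.35 h to 1.6 h. That estimate means a step of a 1.2-fold lower number from compound 3 to compound 4 (0.09 log units; within the scatter), which is expected to stay within the scatter.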

Compound 4, half-life: 0.217 h
Estimate against measurement, compound 4: 3.5-fold (0.54 log units) above, and the stated range ends above it.
By their numbers in this assay, from the lowest: compounds 4, 2, 1 and 3 (each within the scatter of the next, the first and the last beyond it).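

Going by these compounds alone, this is the first change that can be read on its own, and it shows that the group on the aromatic nitrogen matters in this assay, with 4-methoxycyclohexyl in place of 4-aminocyclohexyl giving a 4.2-fold lower number from compound 3 to compound 4 (0.63 log units; beyond the scatter). The rest of the structure stays the same and the six-membered carbon ring remains, so the step belongs to the exchange of the amino group for the methoxy group, which also takes the count of hydrogen-bond donors from 1 to 0. Nothing measured here explains why the compound with the methoxy group disappears faster.

A single exchange cannot show whether the step comes from losing the amine or from adding the methyl ether, and a 4-hydroxycyclohexyl or 4-(dimethylamino)cyclohexyl group at this position would help to separate those two readings. Going by these compounds, it also remains open whether the same exchange would have a similar effect with a different group on the ether oxygen of the shared core, such as the 3-(trifluoromethyl)phenyl group of compound 2.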